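This account rests on a few compounds, and the source may have more. Where it says the series, first, only, none or still open, it means among the compounds named here.

Of the compounds shown here, two have so far been tested in an assay on isolated protein for inhibition of histone deacetylase 4 (Homo sapiens), read by fluorescence, with a stated time of 1 h, tested at 5 uM; on this read-out higher numbers stand for more inhibition at the one concentration tested (going by the name of the read-out) and lower numbers for less inhibition. Compound 1, `O=C(CCCCCCNC(=O)c1ccc(-c2ccc(-c3cc(O)cc(O)c3)cc2)cc1)NO`, gives 0% in this assay. Compound 2, `COc1cc(/C=C/c2ccc(OC)c(NC(=O)CCCCCCC(=O)NO)c2)cc(OC)c1`, gives 39.1% in this assay. Of these two numbers, compound 2 stands highest; the nearest value is that of compound 1, which lies lower by a margin beyond the usual scatter of the measurement. The next compound, compound 3, `COc1cc(/C=C\c2ccc(OC)c(NC(=O)CCCCCCC(=O)NO)c2)cc(OC)c1`, has not yet been measured. The change from compound 2 to compound 3 is this: the two compounds have the same atoms and bonds and differ only in configuration as drawn: 1 of 1 stereo elements differ; a double bond is drawn E in compound 2 and Z in compound 3. Among the compounds with values here, no pair of measured compounds isolates a change of this kind, so the size of such a step cannot be read from the numbers already in hand. A modest drop is expected rather than a gain, and the step is estimated as a number 9.1 percentage points lower from compound 2 to compound 3 (within the scatter), a shift that may well stay within the scatter. Compound 3 is therefore expected to give about 30% in this assay, most likely falling between 10% and 55%.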

Compound 3, a percentage reported as inhibition, at one concentration (the size of the read-out at that concentration, not a potency): 68.1%
Compound 3: the middle estimate sits 38.1 percentage points below what was measured, outside the stated range (above it).
By their numbers in this assay, from the lowest: compound 1; then compound 2; then compound 3.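

Changing only the geometry of the double bond, from E to Z, is enough to move the result in this assay, with a number 29 percentage points higher from compound 2 to compound 3 (beyond the scatter). Within the data shown here, until now, no pair of measured compounds isolated a change of this kind, so this is the first measured size for such a step at this double bond, and the number is higher for the Z form. With the atoms and bonds held constant, the gain can be assigned to the configuration of the double bond rather than to any added or removed group, because nothing else separates the two compounds: the fact that compounds 2 and 3 differ only in the configuration as drawn

This single pair cannot show whether the Z form would keep its higher number if the methoxy groups were replaced by an amine, the hydroxamic acid by a carboxylic acid, or the present chain by a longer chain. Each reading also comes from one concentration and so gives no potency, which leaves open how far the two forms differ across a range of concentrations and why the geometry matters.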